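A few compounds are considered here, and "the series" means these few. Any claim that something is new, unique, unknown or untested is made for them only; others in the source may bear on it.

Series notes in a functional assay (aorta) for antagonist activity, with Oryctolagus cuniculus as the target; a lower number here means a stronger inhibitor, a higher number a weaker inhibitor. Compound 1 `CCCCc1ccc(CNC(=O)NC2CCCCC2)c(=O)n1Cc1ccc(-c2ccccc2-c2nn[nH]n2)cc1` gives 90 nM in this assay, the highest number among the three measured compounds. Compound 2 `CCCCc1ccc(CN(C)S(=O)(=O)c2ccccc2)c(=O)n1Cc1ccc(-c2ccccc2-c2nn[nH]n2)cc1` gives 2 nM, and compound 3 `CCCCc1ccc(CN(Cc2ccccc2)S(C)(=O)=O)c(=O)n1Cc1ccc(-c2ccccc2-c2nn[nH]n2)cc1` gives 2 nM. Exchanging the (cyclohexylcarbamoyl)amino group of compound 1 for a sulfonyl-bearing amino group was rewarded in both measured cases: a 45-fold lower number from compound 1 to compound 2 (1.65 log units; beyond the scatter) and a 45-fold lower number from compound 1 to compound 3 (1.65 log units; beyond the scatter). Between those two, no change at the digits printed from compound 2 to compound 3 (within the scatter), so the two variants cannot be told apart here.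

Compound 4 `CCCCc1ccc(CN(C)S(C)(=O)=O)c(=O)n1Cc1ccc(-c2ccccc2-c2nn[nH]n2)cc1` is not yet measured. Its change from compound 1 is methyl(methylsulfonyl)amino in place of (cyclohexylcarbamoyl)amino on a saturated chain carbon bound to an aromatic carbon. For the measured compounds named here, the group that enters lacks both the phenylsulfonyl of compound 2 and the benzyl of compound 3; no measured step tests a methyl(methylsulfonyl)amino group without an aromatic ring. The two steps that bear on it, a 45-fold lower number from compound 1 to compound 2 (1.65 log units; beyond the scatter) and a 45-fold lower number from compound 1 to compound 3 (1.65 log units; beyond the scatter), both point to a large drop in number, and compound 4 is expected to follow them, though possibly not all the way to the numbers seen for compound 2 and compound 3. For compound 4 the estimated step is an 11-fold lower number from compound 1 to compound 4 (1.05 log units; beyond the scatter), giving an expected value of 8 nM, expected to lie between 2 nM and 40 nM.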

Compound 4, half-maximal inhibitory concentration: 0.2 nM
Compound 4: middle estimate off by 40-fold (1.60 log units), on the high side; measured number below the stated range.
By their numbers in this assay, from the lowest: compound 4; then compounds 2 and 3 (each within the scatter of the next); then compound 1.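

In this assay, the methyl(methylsulfonyl)amino group has no ring, yet the exchange gives a 450-fold lower number from compound 1 to compound 4 (2.65 log units; beyond the scatter), so an aromatic ring in the entering group is not required for the gain over (cyclohexylcarbamoyl)amino at this saturated chain carbon bound to an aromatic carbon. Loss of the phenyl from either side of the sulfonamide also lowers the number: hydrogen in place of phenyl on the saturated chain carbon bound to the sulfonamide nitrogen gives a 10-fold lower number from compound 3 to compound 4 (1.00 log units; beyond the scatter), and methyl in place of phenyl on the sulfonyl sulfur gives a 10-fold lower number from compound 2 to compound 4 (1.00 log units; beyond the scatter). Compound 2 and compound 3 could not be told apart, but both now stand apart from compound 4, so within these three sulfonamides the phenyl-free group gives the lowest number. Nothing available here bears on the reason for these steps.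

The step from the urea combines the loss of the cyclohexyl ring with the change of linking group, and a methylurea would separate the two. As far as these compounds go, it also remains open whether the low number survives a hydrogen on the sulfonamide nitrogen, or an ethyl or trifluoromethyl on the sulfonyl sulfur.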